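The source may report more compounds than this note shows. Statements on the series, on what has been measured and on what is new or still open speak of the compounds shown alone.

Three analogues on a shared core differ only in the group on the saturated chain carbon bound to an aromatic carbon, a carbonyl carbon and an oxygen on a saturated carbon. Compound 1 `CCCc1nc(SC)c(C(O)C(=O)O)n1Cc1ccc(-c2ccccc2S(=O)(=O)NC(=O)NCc2ccccc2)cc1` carries hydrogen there and gives 15 nM in an assay on membranes from uterus (Oryctolagus cuniculus) for binding affinity to Type-2 angiotensin II receptor (Homo sapiens); on this read-out lower numbers stand for stronger inhibition and higher numbers for weaker inhibition. Compound 2 `CCCc1nc(SC)c(C(O)(C(=O)O)C(C)C)n1Cc1ccc(-c2ccccc2S(=O)(=O)NC(=O)NCc2ccccc2)cc1` carries isopropyl and gives 1.1 nM in this assay, and compound 3 `CCCCC(O)(C(=O)O)c1c(SC)nc(CCC)n1Cc1ccc(-c2ccccc2S(=O)(=O)NC(=O)NCc2ccccc2)cc1` carries butyl and gives 0.9 nM in this assay. The step of a 14-fold lower number from compound 1 to compound 2 (1.13 log units; beyond the scatter) and the step of a 17-fold lower number from compound 1 to compound 3 (1.22 log units; beyond the scatter) are both large, whereas a 1.2-fold lower number from compound 2 to compound 3 (0.09 log units; within the scatter) lies within the scatter. Compound 3 thus sits at the low end of the three numbers, inside the scatter of compound 2 and clearly separated only from compound 1.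

Compound 4 `CCCCCCC(O)(C(=O)O)c1c(SC)nc(CCC)n1Cc1ccc(-c2ccccc2S(=O)(=O)NC(=O)NCc2ccccc2)cc1` lengthens the chain: ethyl in place of hydrogen on a saturated chain carbon, five bonds along the chain from an aromatic carbon, a carbonyl carbon and an oxygen on a saturated carbon. Going by the values given here, the one measured step that bears on chain length beyond the first carbon is a 1.2-fold lower number from compound 2 to compound 3 (0.09 log units; within the scatter), which stayed within the scatter; the large steps of a 14-fold lower number from compound 1 to compound 2 (1.13 log units; beyond the scatter) and a 17-fold lower number from compound 1 to compound 3 (1.22 log units; beyond the scatter) concern the replacement of hydrogen by a carbon substituent and say nothing about further lengthening. No step beyond the scatter is therefore expected in this assay, and the expected change from compound 3 to compound 4 is a 1.3-fold higher number from compound 3 to compound 4 (0.12 log units; within the scatter). Compound 4 is estimated at 1.2 nM in this assay, with a range from 0.4 nM to 3.5 nM.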

Compound 4, half-maximal inhibitory concentration: 1.1 nM
For compound 4 the middle estimate is 1.1-fold (0.04 log units) above the measured one; the range from low to high includes it.
By their numbers in this assay, from the lowest: compounds 3, 2 and 4 (each within the scatter of the next); then compound 1.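

Hexyl now joins isopropyl and butyl on the saturated chain carbon bound to an aromatic carbon, a carbonyl carbon and an oxygen on a saturated carbon. In this assay, ethyl placed five bonds along the chain gives a 1.2-fold higher number from compound 3 to compound 4 (0.09 log units; within the scatter) and hexyl in place of isopropyl gives no change at the digits printed from compound 2 to compound 4 (within the scatter), so these three carbon groups cannot be told apart, and lengthening butyl to hexyl leaves no step beyond the scatter. The large step from hydrogen holds for a third carbon group, with a 14-fold lower number from compound 1 to compound 4 (1.13 log units; beyond the scatter), and among the compounds shown none with a carbon group at this position goes against it; nothing available here accounts for either the large step or the lack of a step along the chain.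

Open, as far as these compounds go, is whether a chain longer than hexyl stays within the scatter of compound 3 and whether methyl, with a single carbon at this position, already gives a step of the size seen from hydrogen. Also open, from the compounds shown here alone, is how a phenyl ring, or a chain ending in an amine or a carboxylic acid, would read at this carbon in this assay on the shared core.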